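The source may hold more compounds than are shown below. What is called first, only, known or untested is meant among the compounds shown, and "the series" means these compounds.

Of the compounds shown here, two have been measured so far. Compound 1 `CC(C)(C)Cc1csc(N)c1C(=O)c1cccc(C(F)(F)F)c1` gives 1% in an assay on CHO cells for displacement of a labelled ligand from adenosine receptor A3 (Homo sapiens), read by scintillation counting, tested at 10 uM; on this read-out higher numbers stand for more inhibition at the one concentration tested (going by the name of the read-out) and lower numbers for less inhibition. Compound 2 `CC(C)(C)Cc1c(-c2ccccc2)sc(N)c1C(=O)c1cccc(Cl)c1` gives 5% in this assay; compound 2 and compound 1 sit within the usual scatter of each other, so neither number stands apart.

Compound 3 `CC(C)(C)Cc1c(-c2ccccc2)sc(N)c1C(=O)c1cccc(C(F)(F)F)c1` is the next compound to be measured. It differs from compound 2 by trifluoromethyl in place of chloro on an aromatic carbon. For the measured compounds named here, no measured pair shows this change. Since compound 1 already carries trifluoromethyl and gives 1%, no step beyond the scatter is expected for a number 1 percentage points lower from compound 2 to compound 3 (within the scatter). Compound 3 is estimated at 4%, within -5% to 15%.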

Compound 3, a percentage reported as inhibition, at one concentration (the size of the read-out at that concentration, not a potency): 1%
Estimate against measurement, compound 3: 3 percentage points above; the range from low to high includes it.
By their numbers in this assay, from the lowest: compounds 1, 3 and 2 (each within the scatter of the next).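

Trifluoromethyl in place of chloro on an aromatic carbon, meta to a large group, gives a number 4 percentage points lower from compound 2 to compound 3 (within the scatter) in this assay and so does not separate these two groups here. Phenyl in place of hydrogen on an aromatic carbon gives no change at the digits printed from compound 1 to compound 3 (within the scatter) and so leaves the read-out equally unmoved by this second change. Nothing measured here bears on why both steps stay within the scatter.

From the compounds shown here alone, whether any change at these two places can move the number beyond the scatter remains open. An amine or a carboxylic acid in place of trifluoromethyl would test this at the first place, and a longer chain in place of phenyl at the second.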